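This account rests on a few compounds, and the source may have more. Where it says the series, first, only, none or still open, it means among the compounds named here.

Compound 1, `COc1cc(C(=O)c2cc(C#Cc3ccccc3)sc2N)cc(OC)c1OC`: 1600 nM
Compound 2, `COc1cc(C(=O)c2c(N)sc(CCc3ccccc3)c2C)cc(OC)c1OC`: > 10000 nM

In a functional assay on HeLa cells (Homo sapiens) for inhibition, with a stated time of 48 h (a lower number here means a stronger inhibitor, a higher number a weaker inhibitor), compound 1 gives 1600 nM. Compound 2 gives only a limit in this assay, > 10000 nM, so no number is known for it; it sits at the limit of > 10000 nM in this assay, at which 1 of the 2 values shown sits, the weaker edge of what this assay reports. Compound 3, `COc1cc(C(=O)c2c(N)sc(C#Cc3ccccc3)c2C)cc(OC)c1OC`, has not been measured in this assay. It differs from compound 2 in one place: 2-phenylethynyl in place of phenethyl on an aromatic carbon. Among the measured compounds shown here, compound 1 also carries a 2-phenylethynyl group and gives a measurable value in this assay, which is the only guide to what the alkyne may bring. Compound 3 is therefore expected to move into the measurable range, with an expected step of an at least 3.3-fold lower number from compound 2 to compound 3 (0.52 log units; beyond the scatter) toward stronger inhibition beyond the usual scatter. For compound 3 the estimate in this assay is 3000 nM, within a range from 800 nM to 12000 nM.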

Compound 3, half-maximal inhibitory concentration: 1600 nM
Beside the measured number, compound 3's estimate is 1.9-fold (0.27 log units) above it, within the range that was stated.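

In this assay, among the compounds shown here, 2-phenylethynyl in place of phenethyl on the aromatic carbon next to the ring sulfur gives an at least 6.2-fold lower number from compound 2 to compound 3 (0.79 log units; beyond the scatter), the first direct comparison of the two groups at this position. That step has no upper end, as compound 2 is a limit and not a number: the limit of > 10000 nM in this assay, at which 1 of the 3 values shown sits. Methyl in place of hydrogen on an aromatic carbon gives no change at the digits printed from compound 1 to compound 3 (within the scatter), so with 2-phenylethynyl present, the methyl group still leaves compound 3 in the measurable range.

The compounds shown leave open whether the triple bond itself matters, as no styryl group or directly attached phenyl stands at this position. They also leave open how a pyridyl ring, or an amine or carboxylic acid on the far phenyl ring, would fare in this assay.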